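The source may report more compounds than this note shows. Statements on the series, on what has been measured and on what is new or still open speak of the compounds shown alone.

Of the compounds shown here, three built on one shared core have been tested in a functional assay (Cavia porcellus) with sulfonylurea receptors; K-ATP channels (Homo sapiens) as the target; a lower number here means a stronger inhibitor, a higher number a weaker inhibitor. Compound 1 `CC(O)(C(=O)Nc1cccc(S(=O)(=O)c2ccccc2)c1)C(F)(F)F` reaches only the limit of the assay, > 30000 nM, so no number is known for it. Among the three results, one is the limit of > 30000 nM in this assay, at which 1 of the 3 values shown sits. In this assay compound 2 `CC(O)(C(=O)Nc1ccc(C#N)c(Sc2ccccc2)c1)C(F)(F)F` gives 8300 nM, while compound 3 `CC(O)(C(=O)Nc1ccc(S(=O)(=O)c2ccccc2)c(O)c1)C(F)(F)F` gives 430 nM. Of the two numbers shown, compound 3 holds the lower one, and its distance from compound 2 lies beyond the usual scatter of repeated measurements.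

Compound 4 `CC(O)(C(=O)Nc1ccc(S(=O)(=O)c2ccccc2)c(C(F)(F)F)c1)C(F)(F)F` has not been measured. It differs from compound 3 by trifluoromethyl in place of hydroxy on an aromatic carbon. Among the compounds with values here, no measured pair shows a change of this kind, so the size of the step can only be guessed. Within the data shown here, the hydroxy that leaves is the one group compound 3 carries and compound 1 does not, and compound 1 sits at a limit. The step from compound 3 to compound 4 is therefore expected to weaken inhibition, by about a 7.0-fold higher number from compound 3 to compound 4 (0.84 log units; beyond the scatter). For compound 4 the estimate in this assay is 3000 nM, with a likely range from 500 nM to 30000 nM.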

Compound 4, half-maximal inhibitory concentration: > 30000 nM
Compound 4: only a limit was reported (the forecaster's own chance of this, stated with the estimate: 25%); at least 10-fold (1.00 log units) between middle value and limit.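

In this assay, placing trifluoromethyl where hydroxy stood gives an at least 69-fold higher number from compound 3 to compound 4 (1.84 log units; beyond the scatter), the first step shown between two compounds that differ in one place. Inhibition at this aromatic carbon therefore depends strongly on which of these two groups it carries, a point the earlier compounds could not isolate. The result for compound 4 is a limit and not a number, so the step gives only a minimum size: the limit of > 30000 nM in this assay, at which 2 of the 4 values shown sit.

The compounds shown leave open whether the loss comes from the hydroxy leaving, the trifluoromethyl entering, or both. A comparison on this same aromatic carbon with the rest of compound 3 unchanged, carrying a methoxy, an amine or a single fluorine, would bear on that question.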